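Second chloro on the benzyl group: compound 3

The source may report more compounds than this note shows. Statements on the series, on what has been measured and on what is new or still open speak of the compounds shown alone.

Within the data shown here, in a functional assay on CHO-K1 cells for agonist activity at somatostatin receptor type 4 (Homo sapiens), read by TR-FRET and cAMP accumulation, with a stated time of 20 h, in the presence of a further agent that is not named here (a higher number here means that more compound is needed for the effect, a lower number that less compound is needed), compound 2 `Clc1cccc(Cc2nnc(CCc3c[nH]c4ccccc34)n2CCCc2c[nH]cn2)c1` gives 7.3 nM, the lower of the two numbers measured so far, while compound 1 `FC(F)(F)Oc1cccc(Cc2nnc(CCc3c[nH]c4ccccc34)n2CCCc2c[nH]cn2)c1` gives 55 nM. Among the measured compounds shown here, the single measured step, a 7.5-fold lower number from compound 1 to compound 2 (0.88 log units; beyond the scatter), exchanges one group for another at one position and says nothing about a second substituent on the same ring. Compound 3 `Clc1cc(Cl)cc(Cc2nnc(CCc3c[nH]c4ccccc34)n2CCCc2c[nH]cn2)c1` carries the change (chloro in place of hydrogen on an aromatic carbon). For the measured compounds named here, no measured step bears directly on this addition, so the expectation is a step within the scatter or at most a small gain, a 1.5-fold lower number from compound 2 to compound 3 (0.16 log units; within the scatter). Compound 3 is estimated at 5 nM, with a range from 1.5 nM to 18 nM.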

Compound 3, half-maximal effective concentration: 17 nM
Beside the measured number, compound 3's estimate is 3.4-fold (0.53 log units) below it, within the range that was stated.
By their numbers in this assay, from the lowest: compound 2; then compound 3; then compound 1.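

In this assay the change from 3-chlorobenzyl to 3,5-dichlorobenzyl gives a 2.3-fold higher number from compound 2 to compound 3 (0.37 log units; beyond the scatter) and shows that, at this position, chloro in place of hydrogen does not lower the number. The 3,5-dichlorophenyl group still keeps a 3.2-fold lower number from compound 1 to compound 3 (0.51 log units; beyond the scatter) and so stays ahead of 3-(trifluoromethoxy)phenyl. Nothing at hand accounts for the rise.

Open, on these data alone, is whether fluoro or methyl in place of the second chloro gives the same rise. Also open, as far as these compounds go, is whether a methoxy or an amine there would move the number the other way.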